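This account rests on a few compounds, and the source may have more. Where it says the series, first, only, none or still open, it means among the compounds named here.

Measured so far:
compound 1 `Cn1nc(-c2ccnc(Nc3ccc([N+](=O)[O-])cc3)n2)c2ccccc21` — 11800 nM
compound 2 `Cn1nc(-c2ccnc(Nc3cccc([N+](=O)[O-])c3)n2)c2ccccc21` — 580 nM
compound 3 `Cn1nc(-c2ccnc(Nc3ccc(S(N)(=O)=O)cc3)n2)c2ccccc21` — 940 nM

These three compounds were tested in a functional assay on MCF7 cells (Homo sapiens) for antiproliferative activity, read by MTT assay, with a stated time of 72 h; on this read-out lower numbers stand for stronger inhibition of growth and higher numbers for weaker inhibition of growth. Compound 1 and compound 2 are built from the same atoms joined differently; the difference between the two cores is not broken down here. From compound 1 to compound 3 the change is sulfamoyl in place of nitro on an aromatic carbon, and it brings a 13-fold lower number from compound 1 to compound 3 (1.10 log units; beyond the scatter). Compound 4 `Cn1nc(-c2ccnc(Nc3cccc(S(N)(=O)=O)c3)n2)c2ccccc21` is not yet measured. It differs from compound 2 by sulfamoyl in place of nitro on an aromatic carbon, the same kind of change as from compound 1 to compound 3, but here the group sits meta to a large group rather than para to a large group. Compound 2 and compound 3 lie within the scatter of each other, so the starting point for compound 4 is already low. In this assay compound 4 is expected to give about 300 nM, between 80 nM and 1500 nM. The expected step from compound 2 is a 1.9-fold lower number from compound 2 to compound 4 (0.29 log units; within the scatter), smaller than a 13-fold lower number from compound 1 to compound 3 (1.10 log units; beyond the scatter) because compound 2 starts at 580 nM rather than at the high number of compound 1.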

Compound 4, concentration for 50% growth inhibition: 2270 nM
Beside the measured number, compound 4's estimate is 7.6-fold (0.88 log units) below it, outside the stated range (above it).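

In this assay, the change of nitro to sulfamoyl does not carry from one core to the other: the same change on two cores in this assay, a 13-fold lower number (1.10 log units; beyond the scatter) from compound 1 to compound 3 and a 3.9-fold higher number (0.59 log units; beyond the scatter) from compound 2 to compound 4, 49-fold (1.69 log units) apart, beyond the scatter of two such steps. The earlier step, a 13-fold lower number from compound 1 to compound 3 (1.10 log units; beyond the scatter), and the new step, a 3.9-fold higher number from compound 2 to compound 4 (0.59 log units; beyond the scatter), run in opposite directions, so a step measured on the core of compound 1 cannot be transferred to the core of compound 2 in this series. With only these two pairs, the result shows that the outcome differs between the cores but does not show why, or how the change would behave on any further core. From the compounds shown here alone, it remains open whether an amine or a carboxylic acid in the same place would follow either step. Going by these compounds, whether either group would separate the two cores in the same way also remains open.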